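A Larger Group on the Carbonyl Carbon of Compound 1

The source may report more compounds than this note shows. Statements on the series, on what has been measured and on what is new or still open speak of the compounds shown alone.

Compound 1 `CCc1cc(S(=O)(=O)N2C[C@H](c3ccccc3)NC2=O)ccc1NC(=O)OC` and compound 2 `CCCCOC(=O)Nc1ccc(S(=O)(=O)N2C[C@H](c3ccccc3)NC2=O)cc1CC` share one core and differ only in the chain on the saturated carbon bound to an oxygen next to a carbonyl group. In a functional assay on A549 cells (Homo sapiens) for cytotoxicity, read by MTT assay (on this read-out lower numbers stand for stronger inhibition and higher numbers for weaker inhibition), compound 1 gives 250 nM, and compound 2 gives 200 nM. Of these two numbers compound 1 stands highest, with compound 2 nearest, and the step of a 1.3-fold lower number from compound 1 to compound 2 (0.10 log units; within the scatter) lies within the scatter. Compound 3 `CCc1cc(S(=O)(=O)N2C[C@H](c3ccccc3)NC2=O)ccc1NC(=O)c1ccc([N+](=O)[O-])cc1` has not yet been measured. It differs from compound 1 by 4-nitrophenyl in place of methoxy on a carbonyl carbon, a change on the carbonyl carbon whose other neighbour is an amide-type nitrogen; cut one bond further out, it reads methoxycarbonyl to (4-nitrophenyl)carbonyl. Among the measured compounds shown here, the one measured step concerns a different place, the chain on the oxygen, and was small, so nothing measured here speaks directly to the exchange of methoxy for 4-nitrophenyl. The step of no change at the digits printed from compound 1 to compound 3 (within the scatter) is therefore expected to stay within the scatter, though with little to anchor it the range is wide. The estimate for compound 3 in this assay is 250 nM, from 80 nM to 800 nM.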

Compound 3, half-maximal inhibitory concentration: 700 nM
Beside the measured number, compound 3's estimate is 2.8-fold (0.45 log units) below it; the measured number falls inside the stated range.
By their numbers in this assay, from the lowest: compounds 2 and 1 (each within the scatter of the next); then compound 3.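

In this assay, among the compounds shown here, the exchange on the carbonyl carbon is the first change in this set to go beyond the scatter: the number rises with a 2.8-fold higher number from compound 1 to compound 3 (0.45 log units; beyond the scatter) and also with a 3.5-fold higher number from compound 2 to compound 3 (0.54 log units; beyond the scatter) and both steps are modest, pointing to weaker inhibition. Methoxy and butoxy on this carbonyl carbon gave numbers within the scatter of each other, whereas 4-nitrophenyl in place of either one gives a higher number, so this position does respond to the group placed on the carbonyl carbon, though not steeply in these compounds. Nothing at hand explains this rise.

From the compounds shown here alone, what stays open is whether the rise goes with the six-membered aromatic ring itself or with the nitro group on it, and a plain phenyl or a 4-aminophenyl on the same carbonyl carbon would separate the two. Also open is how an amine in place of methoxy on this carbonyl carbon, or a chain longer than butoxy, would read in this assay against the compounds shown here.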